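The source may report more compounds than this note shows. Statements on the series, on what has been measured and on what is new or still open speak of the compounds shown alone.

Compound 1 `COc1cc(-c2cc(=O)c3cc(O)ccc3o2)cc(OC)c1OC` gives 7.85 ug/mL in a functional assay on HT-29 cells (Homo sapiens) for cytotoxicity, read by MTT assay, with a stated time of 6 days; on this read-out lower numbers stand for an effect already at smaller amounts and higher numbers for an effect only at larger amounts of compound.
Compound 2 `COc1cc(-c2cc(=O)c3ccc(O)cc3o2)cc(OC)c1OC` shows in this assay only a limit of the assay, > 25 ug/mL.
Compound 3 `COc1cc(-c2cc(=O)c3cc(O)ccc3o2)cc(OC)c1O` shows in this assay only a limit of the assay, > 25 ug/mL.

Two of the three values sit at the limit, as noted in the limit of > 25 ug/mL in this assay, at which 2 of the 3 values shown sit, so only compound 1 gives a number. Compound 1 and compound 3 differ in one place: methyl in place of hydrogen on an oxygen on an aromatic ring. Among the measured compounds shown here, the step of an at least 3.1-fold lower number from compound 3 to compound 1 (0.50 log units; beyond the scatter) is the only measured step. How the core of compound 2 differs from the core of compound 3 is not broken down here.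

Compound 4 `COc1ccc2c(=O)cc(-c3cc(OC)c(OC)c(OC)c3)oc2c1` is not yet measured in this assay. For the measured compounds named here, it differs from compound 2 by methyl in place of hydrogen on an oxygen on an aromatic ring, the same change as the one from compound 3 to compound 1, made on the same kind of place, an oxygen on an aromatic ring whose other neighbours are aromatic carbon.

For compound 4 a step of the order of an at least 2.5-fold lower number from compound 2 to compound 4 (0.39 log units; beyond the scatter) is expected, resting on the measured step of an at least 3.1-fold lower number from compound 3 to compound 1 (0.50 log units; beyond the scatter) for the same change. The starting point for this expectation is weak, since for compound 2 only a limit is known, > 25 ug/mL, so the true value of compound 2 may lie anywhere past it and the size of the expected step is uncertain. Compound 4 is therefore estimated at 10 ug/mL, with a wide range from 3 ug/mL to 30 ug/mL, and a sizeable chance that the assay again returns only a limit.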

Compound 4, concentration for half-maximal effect: > 25 ug/mL
Compound 4 was reported as a limit (the forecaster's own chance of this, stated with the estimate: 35%); middle value at least 2.5-fold (0.39 log units) from the limit.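

Compound 2 and compound 4 both return only a limit of the assay, so no step can be read between them: the limit of > 25 ug/mL in this assay, at which 3 of the 4 values shown sit.

The compounds shown leave open how far past that limit compound 2 and compound 4 lie, and whether methyl in place of hydrogen on this oxygen changes the read-out here as it does from compound 3 to compound 1.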